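The source may report more compounds than this note shows. Statements on the series, on what has been measured and on what is new or still open speak of the compounds shown alone.

Working notes on the series. Going by the values given here, in a functional assay on K562 cells (Homo sapiens) for cytotoxicity, read by MTT assay (a lower number here means that less compound is tolerated, a higher number that more compound is tolerated), compound 2 `COC1C=C(CCC/C(C)=C\CC/C(C)=C\CC[C@@H](C)/C=C2\OC(=O)C(C)=C2O)C(OC)O1` gives 83 ug/mL, the only actual number so far. Compound 1 `CC1=C(O)/C(=C/[C@H](C)CC/C=C(/C)CC/C=C(/C)CCCC2=CC(=O)OC2O)OC1=O` is reported only as a limit of the assay, > 100 ug/mL. Compound 3 `CC1=C(O)/C(=C/[C@H](C)CC/C=C(/C)CC/C=C(/C)CCCc2ccoc2)OC1=O` keeps the shared core and chain of compound 2, and the change sits at the chain end: a group of 5 heavy atoms (4 carbon, 1 oxygen; one five-membered aromatic ring with 1 hetero atom) in place of a group of 9 heavy atoms (6 carbon, 3 oxygen; one five-membered non-aromatic ring with 1 hetero atom), on a saturated chain carbon, three bonds along the chain from a double-bonded chain carbon. Among the compounds with values here, one measured step bears on it, at the same place on the chain: an at least 1.2-fold lower number from compound 1 to compound 2 (0.08 log units; that floor lies within the scatter). That step is open on one side because of the limit of > 100 ug/mL in this assay, at which 1 of the 2 values shown sits, and its floor stays within the scatter. Neither measured group is aromatic, so this step gives only a weak guide for furan-3-yl. No shift beyond the scatter is therefore expected in this assay, and no firm direction. The expected change is a 1.3-fold lower number from compound 2 to compound 3 (0.11 log units; within the scatter). The estimate for compound 3 is 65 ug/mL, with an expected range from 25 ug/mL to 130 ug/mL.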

Compound 3, concentration lethal to 50% of the cells: 62 ug/mL
Beside the measured number, compound 3's estimate is 1.0-fold (0.02 log units) above it; the measured number falls inside the stated range.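

At the place on a saturated chain carbon, three bonds along the chain from a double-bonded chain carbon, an aromatic ring now appears in this assay: furan-3-yl in place of the non-aromatic ring of compound 2 gives a 1.3-fold lower number from compound 2 to compound 3 (0.13 log units; within the scatter). Going by these compounds alone, this is the first step at this position with an actual number at both ends, and it shows that this exchange brings no shift beyond the scatter. Compound 1 remains only a limit, so an at least 1.6-fold lower number from compound 1 to compound 3 (0.20 log units; that floor lies within the scatter) stays open on one side, and its true size cannot be read: the limit of > 100 ug/mL in this assay, at which 1 of the 3 values shown sits.

All the groups shown at this position are five-membered rings holding oxygen, so whether any group here can move the number beyond the scatter stays open. An amine, a carboxylic acid, a phenyl ring or a longer chain at this place would bear on that question.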